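A few compounds are considered here, and "the series" means these few. Any claim that something is new, unique, unknown or untested is made for them only; others in the source may bear on it.

Within the three measured members of the series, compound 3 `CN1CCC[C@H]1COc1cncc([N+](=O)[O-])c1` gives the highest number: in an assay on membranes from brain for displacement of a labelled ligand from Neuronal acetylcholine receptor; alpha4/beta2 (Rattus norvegicus) (a lower number here means a stronger inhibitor, a higher number a weaker inhibitor), compound 3 gives 4.65 nM, whereas compound 2 `CN1CCC[C@H]1COc1cncc(Br)c1` gives 0.27 nM and compound 1 `CN1CCC[C@H]1COc1cncc(C(F)(F)F)c1` gives 1.83 nM. Both steps into compound 3 raise the number: a 17-fold higher number from compound 2 to compound 3 (1.24 log units; beyond the scatter) and a 2.5-fold higher number from compound 1 to compound 3 (0.41 log units; beyond the scatter). The bromo compound also lies below the trifluoromethyl compound, a 6.8-fold lower number from compound 1 to compound 2 (0.83 log units; beyond the scatter). Compound 4 `CN1CCC[C@H]1COc1cncc(C(=O)N2CCCC2)c1` carries (pyrrolidin-1-yl)carbonyl in place of nitro on an aromatic carbon. Among the compounds with values here, no measured step exchanges nitro for a carbonyl-bearing group, so the two steps into compound 3 only set the scale; every substituent change made so far moved the number beyond the scatter. For compound 4 a modest further rise is expected, a 2.6-fold higher number from compound 3 to compound 4 (0.41 log units; beyond the scatter), giving an estimate of 12 nM with a range from 2.5 nM to 60 nM.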

Compound 4, inhibition constant: 19.9 nM
The estimate for compound 4 lay 1.7-fold (0.22 log units) below the measured number, within the range that was stated.
By their numbers in this assay, from the lowest: compound 2; then compound 1; then compound 3; then compound 4.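

At this position, two atoms from the ring nitrogen, the (pyrrolidin-1-yl)carbonyl group gives the highest number of the four in this assay: the rise is modest against nitro (a 4.3-fold higher number from compound 3 to compound 4 (0.63 log units; beyond the scatter)) but large against trifluoromethyl (an 11-fold higher number from compound 1 to compound 4 (1.04 log units; beyond the scatter)) and bromo (a 74-fold higher number from compound 2 to compound 4 (1.87 log units; beyond the scatter)). A substituent of 7 heavy atoms containing a five-membered ring therefore remains measurable here, with a clear cost against all three smaller groups. Nothing available explains these steps.

On these data alone, whether the rise follows from the carbonyl or from the pyrrolidine ring stays open. A dimethylamide or a simple ketone at this place would separate the two.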